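The source may report more compounds than this note shows. Statements on the series, on what has been measured and on what is new or still open speak of the compounds shown alone.

In a toxicity assay on THP-1 cells (Homo sapiens) for inhibition (on this read-out lower numbers stand for higher toxicity in this test and higher numbers for lower toxicity in this test), compound 1 `COc1ccc(-c2cnc(NC(=O)c3cccc(OC)c3)n2C)cc1` gives only a limit, > 100000 nM. Compound 2 `COc1ccc(-c2cnc(NC(=O)c3ccccn3)n2C)cc1` likewise gives a limit in this assay, > 100000 nM. Compound 3 `COc1ccc(-c2cnc(NC(=O)C3CCCC3)n2C)cc1` also reaches only a limit in this assay, > 100000 nM. Compound 3 therefore stands where all three measured values sit, namely at the limit of > 100000 nM in this assay, at which 3 of the 3 values shown sit, with no number of its own. The three steps that change the group on the carbonyl carbon, a step that the two limits leave unreadable from compound 1 to compound 2, a step that the two limits leave unreadable from compound 1 to compound 3 and a step that the two limits leave unreadable from compound 2 to compound 3, each connect two limits and carry no readable size or direction.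

Compound 4 `COc1ccc(-c2cnc(NC(=O)CCc3ccccc3)n2C)cc1` is the next compound to be measured, and it differs from compound 3 by phenethyl in place of cyclopentyl on a carbonyl carbon. All three measured steps bear on this change, since each also exchanges the group on the carbonyl carbon, yet none of them shows a step beyond the scatter or any step at all that can be read. On that basis compound 4 is expected to give about 150000 nM in this assay, within 60000 nM to 400000 nM, most likely reported again only as a limit. The step expected from compound 3 to compound 4 is accordingly estimated as a step that the limit leaves unreadable from compound 3 to compound 4.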

Compound 4, half-maximal cytotoxic concentration: > 100000 nM
Compound 4: no number, only a limit; the forecaster's own chance of this, stated with the estimate: 85%; the middle value does not contradict the limit.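

Compound 4 also reaches only a limit in this assay, so its steps from compound 1, compound 2 and compound 3 cannot be read: the limit of > 100000 nM in this assay, at which 4 of the 4 values shown sit. The compounds shown leave open whether exchanging the group on the carbonyl carbon changes this read-out at all, as none of them gives a number.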